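This account rests on a few compounds, and the source may have more. Where it says the series, first, only, none or still open, it means among the compounds named here.

Going by the values given here, compound 2 `CCOc1ccccc1-c1ccc(-c2nc3cnccc3c(N[C@H](CC)C(N)=O)c2C#N)cc1` stands at the top of the two numbers so far in a physicochemical assay for lipophilicity, read by HPLC, at pH 7.5 (a lower number here means a more polar compound, a higher number a more lipophilic compound), where compound 2 gives 3. Its nearest neighbour is compound 1 `CC[C@@H](Nc1c(C#N)c(-c2ccc(-c3cccc(CO)c3)cc2)nc2cnccc12)C(N)=O`, which in this assay gives 2; the change from 3-(hydroxymethyl)phenyl to 2-ethoxyphenyl brought a number 1.00 log units higher from compound 1 to compound 2 (beyond the scatter). Compound 3 `CC[C@@H](Nc1c(C#N)c(-c2ccc(-c3cccc(OC)c3)cc2)nc2cnccc12)C(N)=O` has not yet been measured. It differs from compound 2 in one place: 3-methoxyphenyl in place of 2-ethoxyphenyl on an aromatic carbon. Among the compounds with values here, the one measured step, which swapped a group with a hydrogen-bond donor for one without, bears only loosely on this change, since here the donor and acceptor counts stay the same and the group that enters is one heavy atom smaller than the one that leaves. The step for compound 3 is therefore expected to be small, a number 0.40 log units lower from compound 2 to compound 3 (beyond the scatter), downward. Compound 3 is estimated at 2.6, within 2.1 to 3.1.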

Compound 3, distribution coefficient: 2.7
The estimate for compound 3 lay 0.10 log units below the measured number, within the range that was stated.
By their numbers in this assay, from the lowest: compound 1; then compounds 3 and 2 (each within the scatter of the next).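

In this assay, replacing 2-ethoxyphenyl with 3-methoxyphenyl gave a number 0.30 log units lower from compound 2 to compound 3 (within the scatter), so this change, at a place para to a large group, does not separate the two compounds. Methoxy in place of hydroxymethyl, with the rest of the ring unchanged, gave a number 0.70 log units higher from compound 1 to compound 3 (beyond the scatter), showing that exchanging this small group alone moves the number beyond the scatter, without any change to 2-ethoxyphenyl. No supporting data are available to explain either step.

The compounds shown leave open whether the chain length or the place of the group on the ring matters more, a question that 2-methoxyphenyl and 3-ethoxyphenyl would address. They also leave open how far an amine or a carboxylic acid at this place would shift the number.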